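A few compounds are considered here, and "the series" means these few. Any claim that something is new, unique, unknown or untested is made for them only; others in the source may bear on it.

Measured so far in a functional assay on DU-145 cells (Homo sapiens) for cytotoxicity, read by MTT assay; on this read-out lower numbers stand for stronger inhibition and higher numbers for weaker inhibition
- compound 1 `COc1ccc2cc([C@H](C)c3nnc(SCc4ccc(Cl)cc4)n3-c3ccc(F)cc3)ccc2c1` gives 57400 nM
- compound 2 `COc1ccc2cc([C@H](C)c3nnc(SCc4ccc(C)cc4)n3-c3ccc(F)cc3)ccc2c1` gives 44300 nM
- compound 3 `COc1ccc2cc([C@H](C)c3nnc(SCc4ccc(F)cc4)n3-c3ccc(Cl)cc3)ccc2c1` gives 33600 nM

Compound 3 at 33600 nM lies within the scatter of both compound 1 and compound 2, so the three values form one group. Compound 4 `COc1ccc2cc([C@H](C)c3nnc(SCc4ccc(F)cc4)n3-c3ccc(F)cc3)ccc2c1` is still unmeasured and differs from compound 3 by fluoro in place of chloro on an aromatic carbon in the change from 4-chlorophenyl to 4-fluorophenyl. Among the compounds with values here, only one measured step also removes a chloro from an aromatic carbon: a 1.3-fold lower number from compound 1 to compound 2 (0.11 log units; within the scatter) with methyl entering, and it stays within the scatter. Within the data shown here, no measured step shows fluoro entering. A step beyond the scatter in this assay is therefore not expected, and the estimated step is a 1.2-fold higher number from compound 3 to compound 4 (0.08 log units; within the scatter) and no more. Compound 4 is estimated at 40000 nM with an expected range from 21000 nM to 72000 nM in this series.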

Compound 4, half-maximal inhibitory concentration: 60200 nM
Compound 4: middle estimate off by 1.5-fold (0.18 log units), on the low side; the measured number falls inside the stated range.
By their numbers in this assay, from the lowest: compounds 3, 2, 1 and 4 (each within the scatter of the next).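

In this assay, the exchange of chloro for fluoro on an aromatic carbon can now be read at two places in the series (a 1.8-fold higher number from compound 3 to compound 4 (0.25 log units; within the scatter)) and (a 1.0-fold higher number from compound 1 to compound 4 (0.02 log units; within the scatter)), and both steps stay within the scatter. Fluoro in place of methyl (a 1.4-fold higher number from compound 2 to compound 4 (0.13 log units; within the scatter)) also stays within the scatter, so none of these exchanges separates the compounds. Nothing at hand explains these values.

Going by these compounds, whether an amine or a carboxylic acid on that aromatic carbon would give a step beyond the scatter remains open.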